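The source may report more compounds than this note shows. Statements on the series, on what has been measured and on what is new or still open speak of the compounds shown alone.

In an ADME assay on HEK293 cells (Homo sapiens) for cytotoxicity, read by MTT assay, with a stated time of 48 h (a higher number here means a weaker inhibitor, a lower number a stronger inhibitor), compound 1 `COc1ccc(-c2nc(C)c(C(=O)CSc3nc(-c4cccc(OC)c4)c(C#N)c(=O)[nH]3)s2)cc1` gives 95400 nM and compound 2 `COc1cccc(-c2nc(SCC(=O)c3sc(-c4ccccc4)nc3C)[nH]c(=O)c2C#N)c1` gives 90200 nM as its value. Compound 3 `COc1ccc(-c2nc(SCC(=O)c3sc(-c4ccc(Cl)cc4)nc3C)[nH]c(=O)c2C#N)cc1` is recorded there as "not determined" (no result reported), so it offers no number to start from. Compound 4 `COc1cccc(-c2nc(SCC(=O)c3sc(-c4ccc(Cl)cc4)nc3C)[nH]c(=O)c2C#N)c1` differs from compound 3 by 3-methoxyphenyl in place of 4-methoxyphenyl on an aromatic carbon. Within the data shown here, no measured step makes this change. The nearest evidence is the step of a 1.1-fold lower number from compound 1 to compound 2 (0.02 log units; within the scatter) with hydrogen in place of methoxy, which lies within the scatter. Compounds 1 and 2 also carry the 3-methoxyphenyl group found in compound 4. No size or direction can be expected for the step from compound 3 in this assay without a starting number. Compound 4 is expected near 85000 nM (estimated range 40000 nM to 160000 nM).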

Compound 4, half-maximal inhibitory concentration: 77900 nM
Compound 4: the middle estimate sits 1.1-fold (0.04 log units) above what was measured, within the range that was stated.
By their numbers in this assay, from the lowest: compounds 4, 2 and 1 (each within the scatter of the next).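

In this assay chloro in place of hydrogen gives a 1.2-fold lower number from compound 2 to compound 4 (0.06 log units; within the scatter) and chloro in place of methoxy gives a 1.2-fold lower number from compound 1 to compound 4 (0.09 log units; within the scatter) on the same aromatic carbon. With the 3-methoxyphenyl group in place, that carbon has now carried hydrogen, methoxy and chloro with no listed step beyond the scatter. Nothing measured here offers an explanation for these steps. Compound 3 has no value, so the steps from it cannot be read and the change from 4-methoxyphenyl to 3-methoxyphenyl remains unsized. Going by these compounds, whether an amine or a carboxylic acid on that aromatic carbon would give a step beyond the scatter also remains open.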